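The source may hold more compounds than are shown below. What is called first, only, known or untested is meant among the compounds shown, and "the series" means these compounds.

Among the compounds with values here, compound 1 `N[C@]1(C(=O)O)[C@H]2[C@@H](C[C@H]1OCc1cccc(Cl)c1)[C@]2(F)C(=O)O` gives 3.28 nM in an assay on CHO cells for binding affinity to metabotropic glutamate receptor 2 (Rattus norvegicus) (a lower number here means a stronger inhibitor, a higher number a weaker inhibitor), and stands second highest of the three numbers so far. Compound 2 `N[C@]1(C(=O)O)[C@H]2[C@@H](C[C@H]1OCc1ccc(F)c(F)c1)[C@]2(F)C(=O)O` gives 2.27 nM, and compound 3 `N[C@]1(C(=O)O)[C@H]2[C@@H](C[C@H]1OCc1cc(Cl)cc(Cl)c1)[C@]2(F)C(=O)O` gives 5.61 nM. The steps of a 1.4-fold lower number from compound 1 to compound 2 (0.16 log units; within the scatter) and a 1.7-fold higher number from compound 1 to compound 3 (0.23 log units; within the scatter) both lie within the scatter; only a 2.5-fold higher number from compound 2 to compound 3 (0.39 log units; beyond the scatter) is modest. Compound 4 `N[C@]1(C(=O)O)[C@H]2[C@@H](C[C@H]1OCc1c(Cl)cccc1Cl)[C@]2(F)C(=O)O` differs from compound 1 by 2,6-dichlorophenyl in place of 3-chlorophenyl on a saturated chain carbon bound to an oxygen on a saturated carbon. Within the data shown here, the closest precedent is the added chloro of compound 3, whose step from compound 1 stayed within the scatter, while the 3,5-dichlorophenyl of compound 3 against compound 2 weakened modestly. A small step toward a higher number is therefore expected, a 2.4-fold higher number from compound 1 to compound 4 (0.39 log units; beyond the scatter). Compound 4 is estimated at 8 nM, with a range from 3 nM to 25 nM.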

Compound 4, inhibition constant: 4.3 nM
Compound 4: middle estimate off by 1.9-fold (0.27 log units), on the high side; low and high end bracket the measured number.
By their numbers in this assay, from the lowest: compounds 2, 1, 4 and 3 (each within the scatter of the next, the first and the last beyond it).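

In this assay, 2,6-dichlorophenyl at this position, on a saturated chain carbon bound to an oxygen on a saturated carbon, cannot be told apart from any of the other three aryl groups (a 1.3-fold higher number from compound 1 to compound 4 (0.12 log units; within the scatter); a 1.3-fold lower number from compound 3 to compound 4 (0.12 log units; within the scatter); a 1.9-fold higher number from compound 2 to compound 4 (0.28 log units; within the scatter)). Moving the two chlorines from 3,5-dichlorophenyl to 2,6-dichlorophenyl therefore leaves the number within the scatter. Nothing available explains this tolerance.

The compounds shown leave open how this assay would read an amine or a carboxylic acid on the phenyl ring. On these data alone, a longer chain carrying that ring also remains open.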